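Does a 5-carboxypyrazin-2-yl group keep clearance low?

The source may hold more compounds than are shown below. What is called first, only, known or untested is meant among the compounds shown, and "the series" means these compounds.

Compound 1 `O=C(O)c1cccc(NC(=O)[C@H](CC2CCCC2)n2cnc(C(F)(F)F)c2)n1`: < 8 mL/min/kg
Compound 2 `O=C(O)Cc1ccc(NC(=O)[C@H](CC2CCCC2)n2cnc(C(F)(F)F)c2)nc1`: < 8 mL/min/kg

Within the data shown here, both compounds have been tested in an in vitro ADME assay on microsomes from liver (Homo sapiens) for metabolic stability; on this read-out lower numbers stand for slow clearance and higher numbers for fast clearance. In this assay compound 1 gives < 8 mL/min/kg, which is a limit of the assay and not a number. Compound 2 gives < 8 mL/min/kg, which is also a limit. Among the measured compounds shown here, compound 1 therefore stands at the same limit as the only other compound measured: the limit of < 8 mL/min/kg in this assay, at which 2 of the 2 values shown sit. Neither compound has an exact number, so the two cannot be ranked.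

Compound 3 `O=C(O)c1cnc(NC(=O)[C@H](CC2CCCC2)n2cnc(C(F)(F)F)c2)cn1` has not yet been measured. It differs from compound 1 in one place, with 5-carboxypyrazin-2-yl in place of 6-carboxypyridin-2-yl on an amide-type nitrogen. For the measured compounds named here, no measured pair shows what this swap does, so there is no direct guide to its effect. The expectation rests on compound 1, whose < 8 mL/min/kg is a limit, and no change beyond the usual scatter is expected in this assay. The expected step that the limit leaves unreadable from compound 1 to compound 3 is therefore small. For compound 3 the estimated clearance is 7 mL/min/kg, with an expected range from 4 mL/min/kg to 14 mL/min/kg.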

Compound 3, clearance: < 8 mL/min/kg
Compound 3: no number, only a limit; the forecaster's own chance of this, stated with the estimate: 70%; the middle value is on the limit's open side.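

In this assay compound 3 gives < 8 mL/min/kg, which is a limit of the assay and not a number. Among these compounds, compound 1 also gives only a limit, so no step from compound 1 to compound 3 can be read. Whether 5-carboxypyrazin-2-yl in place of 6-carboxypyridin-2-yl changes clearance at all stays open, with every value at one limit: the limit of < 8 mL/min/kg in this assay, at which 3 of the 3 values shown sit.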